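The compounds below may be only part of what the source reports. "The series", "measured", "known", "first", "only" and "open" are said of these compounds alone.

Measured so far:
compound 1, `CC(C)C(=O)OCOC(=O)C1=C(S[C@@H]2CN[C@H](C(=O)Nc3cccc(C(=O)OCOC(=O)C(C)C)c3)C2)[C@H](C)[C@@H]2[C@@H]([C@@H](C)O)C(=O)N12`, with 3.6% in an ADME assay on the whole organism (strain Beagle) for pharmacokinetics, with Canis familiaris (Canis lupus familiaris) as the target, read by LC-MS, at a dose of 10 mg/kg; a lower number here means that a smaller share of the oral dose reaches the circulation, a higher number that a larger share of the oral dose reaches the circulation
compound 2, `CCOC(=O)C1=C(S[C@@H]2CN[C@H](C(=O)Nc3cccc(C(=O)OCC)c3)C2)[C@H](C)[C@@H]2[C@@H]([C@@H](C)O)C(=O)N12`, with 31.3% in this assay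
compound 3, `C[C@@H](O)[C@H]1C(=O)N2C(C(=O)OCC(F)(F)F)=C(S[C@@H]3CN[C@H](C(=O)Nc4cccc(C(=O)OCC(F)(F)F)c4)C3)[C@H](C)[C@H]12`, with 12% in this assay

Compound 2 stands highest of the three numbers in this assay. Its nearest neighbour is compound 3, whose value lies lower by a gap beyond the scatter, and compound 1 lies further below it, also beyond the scatter. Among the measured compounds shown here, the three differ from one another in more than one place, so no single-point step between measured compounds is available and only the values themselves can be set side by side.

Compound 4, `CCOC(=O)C1=C(S[C@@H]2CN[C@H](C(=O)Nc3cccc(C(=O)OCC)c3)C2)[C@H](C)[C@@H]2[C@@H]([C@@H](C)OC(C)=O)C(=O)N12`, has not yet been measured in this assay. It differs from compound 2 in one place: acetyl in place of hydrogen on an oxygen on a saturated carbon. Everything else in compound 2 remains; only the hydroxy becomes acetoxy. For the measured compounds named here, no measured pair shows what such a change does here. The expected step is a number 6.3 percentage points lower from compound 2 to compound 4 (within the scatter), small, perhaps a slight fall, and not surely beyond the scatter. For compound 4 in this assay the estimate is 25%, with a range from 10% to 42%.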

Compound 4, oral bioavailability: 23.3%
For compound 4 the middle estimate is 1.7 percentage points above the measured one, within the range that was stated.
By their numbers in this assay, from the lowest: compounds 1 and 3 (each within the scatter of the next); then compounds 4 and 2 (each within the scatter of the next).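

Among the compounds shown here, the first pair here that differs in one place gives, in this assay, a number 8 percentage points lower from compound 2 to compound 4 (within the scatter) for acetyl in place of hydrogen on an oxygen on a saturated carbon. At this position, then, hydroxy to acetoxy produces no difference that can be told from the scatter, so the free hydroxy is not required for a reading in the range of compound 2. Nothing at hand bears on what lies behind this result.

The compounds shown leave open whether a longer acyl chain such as butyryl, or an acyl group carrying an amine such as glycyl, would also stay within the scatter of compound 2 on this oxygen. They also leave open whether acetoxy would behave the same way on the other esters of compound 1 and compound 3.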